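A few compounds are considered here, and "the series" means these few. Any claim that something is new, unique, unknown or untested is made for them only; others in the source may bear on it.

Three related compounds have been tested so far in a functional assay on COLO 205 cells (Homo sapiens) for inhibition, read by sulforhodamine B assay, with a stated time of 48 h, tested at 50 uM (on this read-out lower numbers stand for less inhibition of growth and higher numbers for more inhibition of growth at the one concentration tested), and they give a first picture of the series. Compound 2 (`COc1cc(/C=C/C(=O)/C=C/c2ccco2)ccc1OCc1cn(CCCOc2cc(=O)oc3ccccc23)nn1`) gives 59% in this test and stands within the scatter of compound 3 (`COc1cc(/C=C/C(=O)/C=C/c2ccco2)ccc1OCc1cn(CCOc2cc(=O)oc3ccccc23)nn1`), which gives 68% under the same conditions. Compound 1 (`COc1ccc(/C=C/C(=O)/C=C/c2ccc(OCc3cn(CCCCCOc4cc(=O)oc5ccccc45)nn3)c(OC)c2)cc1OC`) gives 43% in the same test and lies beyond the scatter from compound 2.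

The compound still unmeasured, compound 4 (`COc1cc(/C=C/C(=O)/C=C/c2cc(OC)c(OC)c(OC)c2)ccc1OCc1cn(CCCOc2cc(=O)oc3ccccc23)nn1`), departs from compound 2 in one place: 3,4,5-trimethoxyphenyl in place of furan-2-yl on a double-bonded chain carbon bound to a double-bonded chain carbon. Within the data shown here, no two measured compounds differ in one place only, so the effect of this exchange has not been seen directly. Among the measured compounds shown here, the only hint comes from compound 1, at 43% in the same test, which also lacks the furan-2-yl group. It differs from compound 2 elsewhere too, which makes it a weak guide. A modest downward move in this assay is therefore expected, an estimated a number 9 percentage points lower from compound 2 to compound 4 (within the scatter) that may not clear the scatter. For compound 4 the estimated value is 50% within an expected range from 35% to 65% in this test.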

Compound 4, percent growth inhibition at one concentration: 74%
Compound 4: middle estimate off by 24 percentage points, on the low side, outside the stated range (above it).
By their numbers in this assay, from the lowest: compound 1; then compounds 2, 3 and 4 (each within the scatter of the next, the first and the last beyond it).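

In this assay, the series now has its first direct comparison at this position: 3,4,5-trimethoxyphenyl in place of furan-2-yl on a double-bonded chain carbon bound to a double-bonded chain carbon gives a number 15 percentage points higher from compound 2 to compound 4 (beyond the scatter), a modest step. In this pair, furan-2-yl is therefore not required for growth inhibition at the one concentration tested, and the position accepts a six-membered aromatic ring of carbon only, a larger group with more hydrogen-bond acceptors, without any loss on this read-out. No supporting data are available to explain the rise, so this single pair records what the exchange does in this test but not how it does so.

The compounds shown leave open whether the step belongs to the six-membered aromatic ring itself or to its methoxy groups, a question that a plain phenyl group at the same place would help to separate. They also leave open how a ring carrying a dimethylamino group or a carboxylic acid in place of the methoxy groups would behave at this position.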